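Working notes: the step from compound 2 to compound 4

The source may hold more compounds than are shown below. What is called first, only, known or untested is meant among the compounds shown, and "the series" means these compounds.

Measured so far in an ADME assay on Vero cells (Chlorocebus sabaeus) for cytotoxicity, read by MTT assay, with a stated time of 96 h (on this read-out higher numbers stand for lower toxicity in this test and lower numbers for higher toxicity in this test), for this series
compound 1 `C/C(=N\NC(N)=O)c1ccc2[nH]c(-c3ccccc3)nc2c1` gives > 100000 nM (a limit, not a number)
compound 2 `CC(=O)c1ccc2c(c1)nc(-c1ccccc1)n2C1CCCCC1` gives 80000 nM
compound 3 `CC(=O)c1ccc2c(c1)nc(-c1ccoc1)n2C1CCCCC1` gives 80000 nM

Compound 3 stands level with compound 2 at 80000 nM and is its nearest neighbour on the numbers. Compound 4 `C/C(=N\NC(N)=O)c1ccc2c(c1)nc(-c1ccccc1)n2C1CCCCC1` is not yet measured and differs from compound 2 by a group of 7 heavy atoms (3 carbon, 3 nitrogen, 1 oxygen; no ring) in place of a group of 3 heavy atoms (2 carbon, 1 oxygen; no ring), on an aromatic carbon on an aromatic carbon. Among the compounds with values here, the one measured step shows no change at the digits printed from compound 2 to compound 3 (within the scatter) but concerns a different place on the molecule, so it gives only indirect guidance here. Compound 1 carries the same entering group and differs from compound 4 elsewhere. Compound 1 reads > 100000 nM as a limit. Starting from compound 2 at 80000 nM the expected outcome in this assay is no change at the digits printed from compound 2 to compound 4 (within the scatter) with no step beyond the scatter expected. Compound 4 is estimated at 80000 nM with an expected range of 35000 nM to 100000 nM in this series.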

Compound 4, half-maximal cytotoxic concentration: > 100000 nM
Compound 4: only a limit was reported; the forecaster's own chance of this, stated with the estimate: 40%; middle value at least 1.2-fold (0.09 log units) from the limit.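

Replacing acetyl with the group of 7 heavy atoms on this aromatic carbon gives an at least 1.2-fold higher number from compound 2 to compound 4 (0.09 log units; that floor lies within the scatter) in this assay. Within the data shown here, this is the first reading at this position, since the earlier step concerned a different place, and it shows no lower number with the larger group, though no real rise can be claimed from a floor within the scatter. The step between compound 1 and compound 4 cannot be read, as both values are limits, and the series now has more than one compound at that limit: the limit of > 100000 nM in this assay, at which 2 of the 4 values shown sit.

On these data alone, the true size of the change from acetyl at this position stays open. Also open, as far as these compounds go, is how an amine or a carboxylic acid on this aromatic carbon would read in this assay, and how a methyl in place of cyclohexyl on the aromatic nitrogen would read with either group.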